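Working notes on an aromatic-carbon substituent swap

The source may report more compounds than this note shows. Statements on the series, on what has been measured and on what is new or still open speak of the compounds shown alone.

Measured in an ADME assay (liver) for metabolic stability, with Liver microsome (Homo sapiens) as the target, using microsomes and NADPH, with a stated time of 30 min, tested at 1 uM; a lower number here means slower removal, a higher number faster removal of the compound:
- compound 1 `Nc1ccc(S(=O)(=O)N2CCN(c3ncc(C(O)(C(F)(F)F)C(F)(F)F)cc3C#CCO)CC2)cn1` gives < 14 mL.min-1.g-1; this value is a limit of the assay, not a number.
- compound 2 `CC(C)n1cc(-c2cc(C(O)(C(F)(F)F)C(F)(F)F)cnc2N2CCN(S(=O)(=O)c3ccc(N)nc3)CC2)cn1` gives 38 mL.min-1.g-1.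
- compound 3 `Nc1ccc(S(=O)(=O)N2CCN(c3ncc(C(O)(C(F)(F)F)C(F)(F)F)cc3-c3ccccc3O)CC2)cn1` gives 22 mL.min-1.g-1.

Compound 3 stands lowest of the two numbers in this assay. The nearest value belongs to compound 2, and the step is a 1.7-fold lower number from compound 2 to compound 3 (0.24 log units; within the scatter). The only floor in the set is the limit of < 14 mL.min-1.g-1 in this assay, at which 1 of the 3 values shown sits.

The next compound is compound 4 `Cc1nc2cc(-c3cc(C(O)(C(F)(F)F)C(F)(F)F)cnc3N3CCN(S(=O)(=O)c4ccc(N)nc4)CC3)ccc2o1`. The change from compound 3 is 2-methyl-1,3-benzoxazol-5-yl in place of 2-hydroxyphenyl on an aromatic carbon.

Two measured steps replace the 3-hydroxyprop-1-yn-1-yl group with an aromatic group: an at least 2.7-fold higher number from compound 1 to compound 2 (0.43 log units; beyond the scatter) and an at least 1.5-fold higher number from compound 1 to compound 3 (0.19 log units; that floor lies within the scatter). Within the data shown here, the one step that swaps one aromatic group for another is a 1.7-fold lower number from compound 2 to compound 3 (0.24 log units; within the scatter), and that is the step most like the present change. On that basis the step to compound 4 in this assay is expected to be small, if anything a slight rise, and not beyond the scatter: a 1.4-fold higher number from compound 3 to compound 4 (0.13 log units; within the scatter).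

Compound 4 is expected to give 30 mL.min-1.g-1 in this assay, with a range from 14 mL.min-1.g-1 to 65 mL.min-1.g-1.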

Compound 4, intrinsic clearance in microsomes: < 14 mL.min-1.g-1
Compound 4: a limit, no number (the forecaster's own chance of this, stated with the estimate: 10%); at least 2.1-fold (0.33 log units) between middle value and limit.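

At this position, ortho to a large group, 2-methyl-1,3-benzoxazol-5-yl brings the read-out in this assay to the limit of the assay, so an aromatic group here need not give a measurable number, although the aromatic groups of compound 2 and compound 3 do. The change gives an at least 2.7-fold lower number from compound 2 to compound 4 (0.43 log units; beyond the scatter), and against 2-hydroxyphenyl it gives an at least 1.5-fold lower number from compound 3 to compound 4 (0.19 log units; that floor lies within the scatter), so only the first of these steps is established. The step between compound 1 and compound 4 cannot be read, and the 3-hydroxyprop-1-yn-1-yl and 2-methyl-1,3-benzoxazol-5-yl groups now share one limit: the limit of < 14 mL.min-1.g-1 in this assay, at which 2 of the 4 values shown sit.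

As far as these compounds go, the true numbers behind both limits stay open. Also open, from the compounds shown here alone, is whether 1,3-benzoxazol-5-yl without its methyl, or a phenyl carrying an amine, would reach the same limit.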